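Swapping a furan for a phenoxy on a piperidine amide

This account rests on a few compounds, and the source may have more. Where it says the series, first, only, none or still open, it means among the compounds named here.

Compound 1 `O=C(Nc1cccc(-c2ccco2)c1)C1CCCN(C(=O)c2cc(C(F)(F)F)cc(C(F)(F)F)c2)C1` gives the lower of the two results so far in an ADME assay on PC-3 cells (Homo sapiens) for cytotoxicity, read by WST assay, tested at 100 uM (a lower number here means less inhibition, a higher number more inhibition at the concentration tested (going by the name of the read-out)), at 0%. Compound 2 `O=C(Nc1ccc(Cl)cc1)C1CCCN(C(=O)c2cccc(-c3nccs3)c2)C1` sits higher in this assay, at 32%, a gap beyond the usual scatter. Compound 3 `O=C(Nc1cccc(Oc2ccccc2)c1)C1CCCN(C(=O)c2cc(C(F)(F)F)cc(C(F)(F)F)c2)C1` differs from compound 1 only by phenoxy in place of furan-2-yl on an aromatic carbon. Among the measured compounds shown here, no measured pair shows the effect of such a change, so the expected step from compound 1 to compound 3 in this assay is a number 10 percentage points higher from compound 1 to compound 3 (within the scatter), small and not clearly beyond the scatter. For compound 3 the estimated result in this assay is 10%, within a range from 0% to 30%.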

Compound 3, a percentage reported as inhibition, at one concentration (the size of the read-out at that concentration, not a potency): 1%
For compound 3 the middle estimate is 9 percentage points above the measured one; measured number inside the range.
By their numbers in this assay, from the lowest: compounds 1 and 3 (each within the scatter of the next); then compound 2.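

At this position, on an aromatic carbon meta to a large group, this assay gives a number 1 percentage points higher from compound 1 to compound 3 (within the scatter) for phenoxy in place of furan-2-yl. The two compounds therefore cannot be told apart here, and a six-membered aromatic ring held through oxygen reads the same as the five-membered ring. Nothing available explains this result. From the compounds shown here alone, whether the reading at this position would stay the same with an amine or a carboxylic acid remains open, as does whether a longer chain would leave it unchanged.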